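From Methoxy to Fluorophenyl Ketone: Estimating Compound 3

The source may report more compounds than this note shows. Statements on the series, on what has been measured and on what is new or still open speak of the compounds shown alone.

Compound 1 `COc1ccc2c(c1)C(n1ccccc1=O)=CC(C)(C)O2` holds the higher of the two numbers in a functional assay (trachea) with Rattus norvegicus as the target (a higher number here means a more potent compound, by a factor of ten per unit of this negative logarithm, a lower number a less potent compound), where compound 1 gives 5.99. Within the data shown here, its only neighbour is compound 2 `CC1(C)C=C(n2ccccc2=O)c2cc(C(=O)c3cccs3)ccc2O1`, which in this assay gives 5.84; the step of a number 0.15 log units lower from compound 1 to compound 2 (within the scatter) accompanies (thiophen-2-yl)carbonyl in place of methoxy on an aromatic carbon. Compound 3 `CC1(C)C=C(n2ccccc2=O)c2cc(C(=O)c3ccccc3F)ccc2O1` differs from compound 1 by (2-fluorophenyl)carbonyl in place of methoxy on an aromatic carbon. Since this change mirrors that earlier step, a shift no larger than the scatter is expected for compound 3, a number 0.09 log units lower from compound 1 to compound 3 (within the scatter). Compound 3 is therefore estimated at 5.9, with a range from 5.4 to 6.4.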

Compound 3, logarithm of the reciprocal of the active concentration, log(1/C): 6.34
Compound 3: the middle estimate sits 0.44 log units below what was measured; low and high end bracket the measured number.
By their numbers in this assay, from the lowest: compounds 2 and 1 (each within the scatter of the next); then compound 3.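

With (2-fluorophenyl)carbonyl on this aromatic carbon, this assay shows its first change beyond the scatter, a number 0.35 log units higher from compound 1 to compound 3 (beyond the scatter), so replacing methoxy here can raise the number. The group on the carbonyl carbon also makes a difference: 2-fluorophenyl in place of thiophen-2-yl gives a number 0.50 log units higher from compound 2 to compound 3 (beyond the scatter). Nothing measured here gives a reason for either step.

From the compounds shown here alone, it remains open whether a plain phenyl on the carbonyl carbon would match compound 3. Going by these compounds, how an amine or a carboxylic acid on this aromatic carbon would compare also remains open.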